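Replacing the 4-methoxyphenyl group of compound 1

This account rests on a few compounds, and the source may have more. Where it says the series, first, only, none or still open, it means among the compounds named here.

Values in a functional assay on Jurkat cells (Homo sapiens) for antiproliferative activity, read by MTT assay, with a stated time of 72 h; a lower number here means a stronger inhibitor, a higher number a weaker inhibitor:
Compound 1 `COc1ccc(-c2ncnn2-c2cc(OC)c(OC)c(OC)c2)cc1` gives 50 nM
Compound 2 `COc1cc(-c2ncnn2-c2ccc(F)cc2)cc(OC)c1OC` gives > 10000 nM (a limit)
Compound 3 `COc1cc(-c2ncnn2-c2ccc([N+](=O)[O-])cc2)cc(OC)c1OC` gives > 10000 nM (a limit)

Among the compounds with values here, compound 1 gives 50 nM in this assay and is the only compound here with a true number. The other readings stop at the limit of > 10000 nM in this assay, at which 2 of the 3 values shown sit, and provide no numbered step.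

The next compound, compound 4 `COc1cc(-n2ncnc2-c2ccc(Cl)c(Cl)c2)cc(OC)c1OC`, keeps the core of compound 1 and changes one group: 3,4-dichlorophenyl in place of 4-methoxyphenyl on an aromatic carbon. Within the data shown here, the only measured step, a step that the two limits leave unreadable from compound 2 to compound 3, gives no size to carry over to this change. Compound 2 also lacks the 4-methoxyphenyl group and reads > 10000 nM, which is a limit. Compound 3 lacks that group too and reads > 10000 nM, which is also a limit. Both differ from compound 4 in other ways as well, so they offer only a weak warning. A loss of activity is therefore expected in this assay, seen as a higher number, although its size is uncertain. Compound 4 is estimated at 2000 nM, with an expected range from 200 nM to 10000 nM. The estimate implies an expected weakening, a 40-fold higher number from compound 1 to compound 4 (1.60 log units; beyond the scatter), and the assay may return only a limit.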

Compound 4, half-maximal inhibitory concentration: > 10000 nM
Compound 4 ended at the assay's limit; the forecaster's own chance of this, stated with the estimate: 35%; at least 5.0-fold (0.69 log units) between middle value and limit.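

Within the data shown here, this is the first readable step at this position. With the core of compound 1 kept, 3,4-dichlorophenyl in place of 4-methoxyphenyl on an aromatic carbon gives an at least 200-fold higher number from compound 1 to compound 4 (2.30 log units; beyond the scatter) in this assay, even though the two groups have the same number of heavy atoms and each holds one six-membered aromatic ring, and the entering group has no hydrogen-bond acceptor.

Compound 4 reads > 10000 nM, which is a limit and not a number.

The step therefore shows that this single change costs a great deal of activity, but its full size stays unknown because the reading stops at the assay's ceiling: the limit of > 10000 nM in this assay, at which 3 of the 4 values shown sit.

The compounds shown leave open whether the loss goes with the arrival of the two chlorine atoms or with the departure of the methoxy oxygen, as the change replaces both at once. A phenyl ring carrying a single chlorine, a hydroxyl, an amine or an ethoxy chain at this place could begin to separate the two and show how much change this position tolerates.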